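Methoxyphenyl in Place of Hydroxyalkyl: Expected Cytotoxicity

A few compounds are considered here, and "the series" means these few. Any claim that something is new, unique, unknown or untested is made for them only; others in the source may bear on it.

Compound 1 `CC(C)(O)c1cn(CC(=O)NCc2ccccc2)nn1` carries a 1-hydroxy-1-methylethyl group on its five-membered aromatic core. Within the data shown here, in an ADME assay on cells (spleen, Mus musculus, strain C57BL/6) for inhibition, read by flow cytometry and propidium iodide staining, with a stated time of 24 h, at 37 degrees C (on this read-out higher numbers stand for an effect only at larger amounts of compound and lower numbers for an effect already at smaller amounts), compound 1 gives 1600 uM, and this is the only plain number among the three measured compounds. Of the other two entries, one is a boundary of the measurement and the third carries no number at all. Compound 2 `NCc1cn(CC(=O)NCc2ccccc2)nn1` bears an aminomethyl at the same place; in this assay compound 2 reaches only the limit > 2000 uM, a boundary of the measurement rather than a number. The step of an at least 1.2-fold higher number from compound 1 to compound 2 (0.09 log units; that floor lies within the scatter) therefore has a floor that sits within the scatter, and the limit of > 2000 uM in this assay, at which 1 of the 3 values shown sits, keeps it from being sized further. Compound 3 `COc1cc(OC)cc(-c2cn(CC(=O)NCc3ccccc3)nn2)c1` carries a 3,5-dimethoxyphenyl on the same carbon and is reported in this assay as "non-toxic" (no number reported).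

Compound 4 `COc1ccc(-c2cn(CC(=O)NCc3ccccc3)nn2)cc1` differs from compound 1 by 4-methoxyphenyl in place of 1-hydroxy-1-methylethyl on an aromatic carbon. Among the measured compounds shown here, no measured step covers an aryl group entering at this position with a number on both sides; the one step that touches this carbon is small at its floor, and compound 3 with a related aryl group gave no toxic effect. Compound 4 is therefore expected to show at most a modest step, a 1.3-fold higher number from compound 1 to compound 4 (0.10 log units; within the scatter), toward a higher number. The estimate for compound 4 is 2000 uM, with a range from 1000 uM to 4000 uM, and a limit rather than a number is thought likely.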

Compound 4, concentration for half-maximal effect: "non-toxic" (no number reported)
Compound 4: no number reported; no gap can be computed for the estimate.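

In this assay, among these compounds, compound 4, like compound 3, is reported as "non-toxic" without a number, so no new step from compound 1 or compound 2 to compound 4 can be read. The compounds shown leave open how large a number compound 3 and compound 4, with their aryl groups on this carbon, would give.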